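This account rests on a few compounds, and the source may have more. Where it says the series, first, only, none or still open, it means among the compounds named here.

Measured in a functional assay on HOS cells (Homo sapiens) for antiproliferative activity, read by sulforhodamine B assay; on this read-out lower numbers stand for stronger inhibition of growth and higher numbers for weaker inhibition of growth:
- compound 1 `CC[C@@H]1O[C@H](COCc2ccccc2)[C@@H](OCc2ccccc2)[C@H](OCc2ccccc2)C1=O`: 4300 nM
- compound 2 `CC(C)C[C@@H]1O[C@H](COCc2ccccc2)[C@@H](OCc2ccccc2)[C@H](OCc2ccccc2)C1=O`: > 50000 nM

Compound 2 stands only at a limit, (the limit of > 50000 nM in this assay, at which 1 of the 2 values shown sits). Compound 3 `CCCCC[C@@H]1O[C@H](COCc2ccccc2)[C@@H](OCc2ccccc2)[C@H](OCc2ccccc2)C1=O` differs from it by butyl in place of isopropyl on a saturated chain carbon bound to a saturated ring carbon. Going by the values given here, one measured step bears on this, an at least 11-fold higher number from compound 1 to compound 2 (1.06 log units; beyond the scatter), which is large and beyond the scatter, and it lies at this same place. It points to weak inhibition in this assay, so only a modest move towards a lower number is expected. The expected step is an at least 2.0-fold lower number from compound 2 to compound 3 (0.30 log units; that floor lies within the scatter). For compound 3 the estimate is 25000 nM, with an expected range of 5000 nM to 50000 nM.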

Compound 3, concentration for 50% growth inhibition: > 50000 nM
Compound 3 gave a limit, no number (the forecaster's own chance of this, stated with the estimate: 45%); middle value at least 2.0-fold (0.30 log units) away from the limit.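

In this assay, the loss seen with the branched isobutyl chain also appears with the straight pentyl chain, with an at least 11-fold higher number from compound 1 to compound 3 (1.06 log units; beyond the scatter). Compound 3 gives > 50000 nM, which is a limit and not a number. The step from compound 2 to compound 3 cannot be read, because both compounds sit at the same limit: the limit of > 50000 nM in this assay, at which 2 of the 3 values shown sit.

The compounds shown leave open whether isobutyl and pentyl differ at all in this assay. They also leave open whether an amine or a carboxylic acid at the end of the chain would bring a measurable value back at this place.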